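This account rests on a few compounds, and the source may have more. Where it says the series, first, only, none or still open, it means among the compounds named here.

Measured in a physicochemical assay for solubility, read by HPLC, at pH 6.8; a higher number here means a more soluble compound, a lower number a less soluble compound:
- compound 1 `COCCNC(=O)c1cnn(-c2cccc3cc(Cc4cccc(C(F)(F)F)c4)sc23)c1`: < 0.08 ug/mL, a limit
- compound 2 `COCCNC(=O)c1cn(-c2cccc3cc(Cc4cccc(C(F)(F)F)c4)sc23)nc1C`: < 0.1 ug/mL, a limit
- compound 3 `COCCNC(=O)c1cnn(-c2cccc3cc(Cc4cccc(C(F)(F)F)c4)sc23)c1C`: 1.3 ug/mL

Among the measured compounds shown here, compound 3, at 1.3 ug/mL, holds the only true number here. The other two values are limits. Compound 4 `COCCNC(=O)c1c(C)nn(-c2cccc3cc(Cc4cccc(C(F)(F)F)c4)sc23)c1C` differs from compound 3 by one change: methyl in place of hydrogen on an aromatic carbon. In words, this is methyl in place of hydrogen on an aromatic carbon.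

Two measured steps make this same kind of swap. The first is an at least 16-fold higher number from compound 1 to compound 3 (1.21 log units; beyond the scatter), well beyond the usual scatter of the measurement. The second is a step that the two limits leave unreadable from compound 1 to compound 2, and the methyl that compound 4 gains matches this second swap, not the first. For the measured compounds named here, the large gain therefore cannot simply be counted a second time, and the only close precedent gives no size. No step beyond the scatter is expected in this assay, and no direction can be favoured with confidence. The estimated result is a 1.3-fold lower number from compound 3 to compound 4 (0.11 log units; within the scatter). For compound 4 the estimate is 1 ug/mL, with an expected range from 0.2 ug/mL to 5 ug/mL.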

Compound 4, solubility: 2.9 ug/mL
Estimate against measurement, compound 4: 2.9-fold (0.46 log units) below; the measured number falls inside the stated range.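

At the aromatic carbon next to the ring nitrogen, methyl in place of hydrogen now has a readable size in this assay: with the other methyl already present, it gives a 2.2-fold higher number from compound 3 to compound 4 (0.35 log units; beyond the scatter), a modest step beyond the scatter. The value of compound 2 is a limit and not a number: the limit of < 0.1 ug/mL in this assay, at which 1 of the 4 values shown sits. With the methyl at this carbon held in place, adding the other methyl gives an at least 29-fold higher number from compound 2 to compound 4 (1.46 log units; beyond the scatter), so a large step like the one seen without the methyl at this carbon appears here too.

As far as these compounds go, the step from compound 1 to compound 2 still cannot be read, so the effect of this methyl without the other methyl stays open. Also open, from the compounds shown here alone, is how this assay would respond to an ethyl, a longer chain or an amine at this same carbon.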